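Ester in place of amide on the shared core

The source may hold more compounds than are shown below. What is called first, only, known or untested is meant among the compounds shown, and "the series" means these compounds.

Measured compounds:
- compound 1, `CCOC(=O)CN(C)C(=O)c1ccc(C(CC)(CC)c2ccc(OCC(O)C(C)(C)C)c(C)c2)n1CC`: 12200 nM
- compound 2, `C#CC(C)OC(=O)c1ccc(C(CC)(CC)c2ccc(OCC(O)C(C)(C)C)c(C)c2)n1CC`: > 50000 nM
- compound 3, `CC[C@@H](C)[C@H](NC(=O)c1ccc(C(CC)(CC)c2ccc(OCC(O)C(C)(C)C)c(C)c2)n1CC)C(=O)O`: 3400 nM

In a functional assay on Caco-2 cells (Homo sapiens), read by MTT assay, with a stated time of 48 h (on this read-out lower numbers stand for stronger inhibition and higher numbers for weaker inhibition), compound 1 gives 12200 nM. Among the numbers shown compound 1 stands highest; its nearest neighbour is compound 3, which gives 3400 nM, and the step is a 3.6-fold lower number from compound 1 to compound 3 (0.55 log units; beyond the scatter). Compound 2 reaches only (the limit of > 50000 nM in this assay, at which 1 of the 3 values shown sits), which is a limit of this assay and not a number. The step from the amide of compound 1 to the ester of compound 2 is an at least 4.0-fold higher number from compound 1 to compound 2 (0.61 log units; beyond the scatter).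

Compound 4, `CCn1c(C(=O)Oc2ccc(CCO)cc2)ccc1C(CC)(CC)c1ccc(OCC(O)C(C)(C)C)c(C)c1`, has not been measured. It differs from compound 1 as follows: a group of 10 heavy atoms (8 carbon, 2 oxygen; one six-membered aromatic ring of carbon only) in place of a group of 8 heavy atoms (5 carbon, 1 nitrogen, 2 oxygen; no ring), on a carbonyl carbon. The change thus swaps the amide of compound 1 for an ester, as the step to compound 2 did, where the number rose at least modestly. The step to compound 3, which kept an amide, went the other way. Among the measured compounds shown here, the closer parallel is the ester, so a rise in number is expected, though the aromatic ring entering here has no precedent among the measured compounds.

For compound 4 the estimated result is a 2.5-fold higher number from compound 1 to compound 4 (0.39 log units; beyond the scatter), giving an expected value of 30000 nM with a range from 8000 nM to 100000 nM.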

Compound 4, half-maximal inhibitory concentration: > 50000 nM
Compound 4: only a limit was reported; the forecaster's own chance of this, stated with the estimate: 40%; middle value at least 1.6-fold (0.22 log units) away from the limit.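

Like compound 2, compound 4 ends at a limit of this assay and not at a number: the limit of > 50000 nM in this assay, at which 2 of the 4 values shown sit.

On this carbonyl carbon, a second ester, now with 4-(2-hydroxyethyl)phenyl on the oxygen, moves in the same direction as the first, with an at least 4.0-fold higher number from compound 1 to compound 4 (0.61 log units; beyond the scatter), and it also stands clearly apart from the amide that carries the (1-carboxy-2-methylbutyl)amino group, with an at least 14-fold higher number from compound 3 to compound 4 (1.16 log units; beyond the scatter). Both esters shown therefore end at the limit while both amides give numbers, a pattern that holds for these four compounds with none against it, and the two limits leave the step from compound 2 to compound 4 unreadable.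

The compounds shown leave open whether the change of linking atom alone accounts for this split, a question that an amide bearing the same 4-(2-hydroxyethyl)phenyl group on its nitrogen could address. They also leave open whether an ester carrying a carboxylic acid on its side chain, or a basic amine there, would give a number in this assay rather than a limit.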